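Carbonyl substituent changes on the shared core

The source may hold more compounds than are shown below. What is called first, only, known or untested is meant among the compounds shown, and "the series" means these compounds.

Of the compounds shown here, three sharing one core have been measured in an assay on membranes from CHO cells for displacement of a labelled ligand from adenosine receptor A1 (Homo sapiens), read by scintillation counting, with a stated time of 60 min, tested at 1 uM; on this read-out higher numbers stand for more inhibition at the one concentration tested (going by the name of the read-out) and lower numbers for less inhibition. Compound 3 `CC1=C(C(=O)CC(C)C)C(c2ccsc2)NC(=O)N1` gives 37%, the highest of the three numbers. Compound 1 `CC1=C(C(=O)OC(C)(C)C)C(c2ccsc2)NC(=O)N1` gives 15%, and compound 2 `CC1=C(C(=O)C2CC2)C(c2ccsc2)NC(=O)N1` gives 2%. Every step among them sits on the carbonyl carbon: a number 13 percentage points lower from compound 1 to compound 2 (beyond the scatter), a number 22 percentage points higher from compound 1 to compound 3 (beyond the scatter), and a number 35 percentage points higher from compound 2 to compound 3 (beyond the scatter). Compound 4 `CC1=C(C(N)=O)C(c2ccsc2)NC(=O)N1` continues on the same carbonyl carbon: amino in place of isobutyl on a carbonyl carbon. The three measured steps show that what sits on this carbonyl carbon moves the read-out by modest to large amounts, and that the isobutyl of compound 3 stands above both alternatives tried so far. Within the data shown here, no measured step puts a one-heavy-atom group carrying a hydrogen-bond donor there, so the direction rests only on the observation that each replacement of the isobutyl seen so far, in compound 1 and compound 2, gave a lower number. A drop beyond the scatter is therefore expected, a number 29 percentage points lower from compound 3 to compound 4 (beyond the scatter). Compound 4 is expected to give 8%, within 0% to 30%.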

Compound 4, a percentage reported as inhibition, at one concentration (the size of the read-out at that concentration, not a potency): 2%
The estimate for compound 4 lay 6 percentage points above the measured number, within the range that was stated.
By their numbers in this assay, from the lowest: compounds 2 and 4 (each within the scatter of the next); then compound 1; then compound 3.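

Amino on the carbonyl carbon gives a number 35 percentage points lower from compound 3 to compound 4 (beyond the scatter) and a number 13 percentage points lower from compound 1 to compound 4 (beyond the scatter) in this assay and so leaves the isobutyl of compound 3 above three alternatives, one of them a group with a hydrogen-bond donor. The comparison with cyclopropyl shows no change at the digits printed from compound 2 to compound 4 (within the scatter) so these two groups cannot be told apart on this read-out, and two quite different replacements share the low end of the series. No supporting data bear on why the number falls with this change.

Going by these compounds, how a longer chain such as isopentyl, or a methylamino group, would read on this carbonyl carbon stays open. Also open, on these data alone, is whether the low number of compound 4 goes with the entering donor or with the loss of the isobutyl chain.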